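Changing the Aromatic Group on a Saturated Ring Carbon

This account rests on a few compounds, and the source may have more. Where it says the series, first, only, none or still open, it means among the compounds named here.

Of the compounds shown here, two sharing one core have been measured in a functional assay on CHO cells for positive allosteric modulation of metabotropic glutamate receptor 2 (Homo sapiens), with a stated time of 30 min; a higher number here means that more compound is needed for the effect, a lower number that less compound is needed. Compound 1, `N#Cc1c(N2CCC(c3ccc(F)cc3)CC2)ccn(CC2CC2)c1=O`, carries a 4-fluorophenyl group on a saturated ring carbon, and in this assay compound 1 gives 89 nM. Compound 2, `N#Cc1c(N2CCC(c3ccccc3Cl)CC2)ccn(CC2CC2)c1=O`, carries a 2-chlorophenyl group at the same place, and in this assay compound 2 gives 49 nM. The step between them is a 1.8-fold lower number from compound 1 to compound 2 (0.26 log units; within the scatter), so the two numbers cannot be told apart with confidence. Compound 2 thus holds the lower of the two numbers, but only by an amount that repeated measurement could erase.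

Compound 3, `COc1ccc(C2CCN(c3ccn(CC4CC4)c(=O)c3C#N)CC2)cc1`, differs from compound 2 in one place: 4-methoxyphenyl in place of 2-chlorophenyl on a saturated ring carbon. Among the compounds with values here, only one measured step bears on this kind of exchange, namely a 1.8-fold lower number from compound 1 to compound 2 (0.26 log units; within the scatter), which swapped one substituted phenyl for another without moving the number beyond the scatter. On that basis the expected step in this assay is a 1.8-fold higher number from compound 2 to compound 3 (0.26 log units; within the scatter), meaning no shift beyond the scatter in either direction. Compound 3 is therefore estimated to give about 90 nM in this assay, with a plausible range from 35 nM to 250 nM.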

Compound 3, half-maximal effective concentration: 98 nM
The estimate for compound 3 lay 1.1-fold (0.04 log units) below the measured number; measured number inside the range.
By their numbers in this assay, from the lowest: compounds 2, 1 and 3 (each within the scatter of the next).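

The exchange of 2-chlorophenyl for 4-methoxyphenyl on this saturated ring carbon gives a 2.0-fold higher number from compound 2 to compound 3 (0.30 log units; within the scatter) in this assay, even though the computed count moves from 0 hydrogen-bond acceptors to 1. Methoxy in place of fluoro on an aromatic carbon, with the phenyl ring otherwise the same, gives a 1.1-fold higher number from compound 1 to compound 3 (0.04 log units; within the scatter), so the numbers for all three substituted phenyl groups shown at this position cannot be told apart. No measurement at hand explains why these numbers lie so close together.

On these data alone, all three compounds keep a phenyl ring at this carbon, so it remains open what would follow if an amine or a carboxylic acid were placed on that ring, or if a longer chain stood in its place. The substituent's identity also cannot be separated from its place on the phenyl ring, and a 4-chlorophenyl group would bear directly on that question, since it could be compared with both 2-chlorophenyl and 4-fluorophenyl.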